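The compounds below may be only part of what the source reports. "The series", "measured", "known", "first", "only" and "open" are said of these compounds alone.

Compound 1, `CCCCCCCCCCCCn1nnc(C(NC(=O)c2ccccc2)c2ccccc2)n1`: 350 nM
Compound 2, `CCCCCCCCCCCCn1nnc(C(NC(=O)c2cccc(Cl)c2)c2ccccc2)n1`: 250 nM

Both were tested in an assay on microsomes from liver for inhibition of sterol O-acyltransferase 1 (Rattus norvegicus); a higher number here means a weaker inhibitor, a lower number a stronger inhibitor. Compound 2 has the lowest of the two numbers, but its gap to compound 1, a 1.4-fold lower number from compound 1 to compound 2 (0.15 log units; within the scatter), lies within the scatter, so the two cannot be told apart. Compound 3, `CCCCCCCCCCCCn1nnc(C(NC(=O)c2ccc([N+](=O)[O-])cc2)c2ccccc2)n1`, carries 4-nitrophenyl in place of 3-chlorophenyl on a carbonyl carbon. Among the compounds with values here, the only measured step, a chloro in place of hydrogen, changed nothing beyond the scatter, and no step with a nitro group exists here, so no shift beyond the scatter is expected in this assay. Compound 3 is therefore expected to give 300 nM, within 110 nM to 850 nM. This expectation amounts to a step of a 1.2-fold higher number from compound 2 to compound 3 (0.08 log units; within the scatter).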

Compound 3, half-maximal inhibitory concentration: 540 nM
The estimate for compound 3 lay 1.8-fold (0.26 log units) below the measured number; measured number inside the range.
By their numbers in this assay, from the lowest: compounds 2, 1 and 3 (each within the scatter of the next, the first and the last beyond it).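

In this assay, within the data shown here, the change from 3-chlorophenyl to 4-nitrophenyl on the carbonyl carbon gives the first step at this position beyond the scatter, though a modest one (a 2.2-fold higher number from compound 2 to compound 3 (0.33 log units; beyond the scatter)). Adding the nitro group alone stays within the scatter (a 1.5-fold higher number from compound 1 to compound 3 (0.19 log units; within the scatter)), so this position tolerates the nitro group without a clear loss. No measurement offered here explains the difference. From the compounds shown here alone, whether the gap follows the group or its place on the ring stays open, since both differ between compound 2 and compound 3. An amine or a carboxylic acid on this ring could also show whether the number can shift further.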